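The source may report more compounds than this note shows. Statements on the series, on what has been measured and on what is new or still open speak of the compounds shown alone.

Measured in a toxicity assay on Vero cells (Chlorocebus sabaeus) for cytotoxicity, read by MTT assay; a lower number here means a stronger inhibitor, a higher number a weaker inhibitor:
Compound 1 `COC(=O)NC(=O)c1ccsc1NC(=O)c1ccc(S(=O)(=O)N2CCC2)cc1`: 17.5 ug/mL
Compound 2 `COC(=O)NC(=O)c1ccsc1NC(=O)c1ccc(S(=O)(=O)NC2CCOCC2)cc1`: 35.7 ug/mL
Compound 3 `COC(=O)NC(=O)c1ccsc1NC(=O)c1ccc(S(=O)(=O)N(C)C)cc1`: 16.2 ug/mL

Compound 3, at 16.2 ug/mL, cannot be told apart from compound 1, as the step of a 1.1-fold lower number from compound 1 to compound 3 (0.03 log units; within the scatter) shows. Both stand below compound 2, which gives 35.7 ug/mL, and the step to the dimethylamino member reads a 2.2-fold lower number from compound 2 to compound 3 (0.34 log units; beyond the scatter).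

The next member is compound 4 `CCN(C)S(=O)(=O)c1ccc(C(=O)Nc2sccc2C(=O)NC(=O)OC)cc1`. Its change is methyl in place of hydrogen on a saturated chain carbon bound to a sulfonamide nitrogen, so dimethylamino becomes ethyl(methyl)amino. Among the measured compounds shown here, no measured pair makes this exact change, so the evidence is indirect. The swap between azetidin-1-yl and dimethylamino gave a 1.1-fold lower number from compound 1 to compound 3 (0.03 log units; within the scatter), which is no step beyond the scatter. For the measured compounds named here, the only steps beyond it involve (oxan-4-yl)amino, and they are modest: a 2.0-fold higher number from compound 1 to compound 2 (0.31 log units; beyond the scatter) and a 2.2-fold lower number from compound 2 to compound 3 (0.34 log units; beyond the scatter). Going by the values given here, with only three compounds, this is thin support for any trend. Even so, a single added methyl is not expected to move the number in this assay by more than those modest steps, and no step beyond the scatter is expected in either direction. The expected step is a 1.1-fold higher number from compound 3 to compound 4 (0.05 log units; within the scatter). Compound 4 is expected at 18 ug/mL, with an estimated range of 9 ug/mL to 35 ug/mL.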

Compound 4, half-maximal inhibitory concentration: 10.4 ug/mL
For compound 4 the middle estimate is 1.7-fold (0.24 log units) above the measured one; measured number inside the range.
By their numbers in this assay, from the lowest: compounds 4, 3 and 1 (each within the scatter of the next); then compound 2.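

In this assay, among the compounds shown here, methyl in place of hydrogen on a saturated chain carbon bound to a sulfonamide nitrogen gives a 1.6-fold lower number from compound 3 to compound 4 (0.19 log units; within the scatter), the first direct reading of this change, and it shows that the extension from dimethylamino to ethyl(methyl)amino does not separate the two compounds. For the compounds shown here, the azetidin-1-yl member also stays level with the new compound, at a 1.7-fold lower number from compound 1 to compound 4 (0.23 log units; within the scatter), so compounds 1, 3 and 4 form one group in which the three sulfonyl substituents cannot be told apart, while compound 2 alone stands apart, and the largest step so far is a 3.4-fold lower number from compound 2 to compound 4 (0.54 log units; beyond the scatter). No supporting measurement bears on the origin of these differences.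

A longer chain such as propyl or butyl on the sulfonamide nitrogen, or a chain ending in an amine or a carboxylic acid, would test whether this tolerance of added carbon extends beyond a single methyl. On these data alone, it also remains open whether the gap at compound 2 follows (oxan-4-yl)amino specifically, a question that cyclohexylamino or morpholin-4-yl on the sulfonyl sulfur could help to settle.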